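This account rests on a few compounds, and the source may have more. Where it says the series, first, only, none or still open, it means among the compounds named here.

Measured compounds:
compound 1 `COc1cc(-c2cc(/C=C/C(=O)c3ccc(N)cc3)[nH]n2)cc(OC)c1OC`, 3680 nM
compound 2 `COc1ccc(-c2cc(/C=C/C(=O)c3ccc(OC)c(OC)c3)[nH]n2)cc1`, "not determined" (no result reported)

For the measured compounds named here, compound 1 is the only compound with a number in a functional assay on HOP-92 cells (Homo sapiens) for inhibition, read by sulforhodamine B assay, with a stated time of 48 h; on this read-out higher numbers stand for weaker inhibition of growth and lower numbers for stronger inhibition of growth; compound 2 was run without a reported result, so compound 1 stands alone and cannot be ranked. Compound 3 `COc1cc(-c2cc(/C=C/C(=O)c3ccc(Cl)c(Cl)c3)[nH]n2)cc(OC)c1OC` shares the core of compound 1 and differs in one place: 3,4-dichlorophenyl in place of 4-aminophenyl on a carbonyl carbon. Going by the values given here, no measured step of this kind is available, so the expectation rests on compound 1 alone. Compound 3 is expected to sit close to compound 1 in this assay, with a step of a 1.2-fold lower number from compound 1 to compound 3 (0.09 log units; within the scatter) that may not exceed the usual scatter. Compound 3 is therefore estimated at 3000 nM, in the range 800 nM to 12000 nM.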

Compound 3, concentration for 50% growth inhibition: 2530 nM
Beside the measured number, compound 3's estimate is 1.2-fold (0.07 log units) above it; the range from low to high includes it.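

In this assay the exchange of 4-aminophenyl for 3,4-dichlorophenyl on a carbonyl carbon gives a 1.5-fold lower number from compound 1 to compound 3 (0.16 log units; within the scatter) and so shows that this position accepts the swap with no difference beyond the scatter. The read-out holds level even though the entering group has no hydrogen-bond donor or acceptor, while the leaving group has one of each. Nothing available explains this result. On these data alone, whether a carboxylic acid or a longer chain at this position would give a step beyond the scatter remains open.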